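From a Methylphenyl to a Chlorinated Trifluoromethylphenyl Group

The compounds below may be only part of what the source reports. "The series", "measured", "known", "first", "only" and "open" are said of these compounds alone.

Of the compounds shown here, two have been measured so far in an ADME assay on HEK293 cells (Homo sapiens) for cytotoxicity, read by MTT assay, with a stated time of 24 h; on this read-out lower numbers stand for stronger inhibition and higher numbers for weaker inhibition. Compound 1 (`CN1CCN(c2nc3cc([N+](=O)[O-])ccc3nc2NCc2ccc(C(F)(F)F)cc2)CC1`) gives 6.99 ug/mL, while compound 2 (`Cc1ccc(CNc2nc3ccc([N+](=O)[O-])cc3nc2NCCCN(C)C)cc1`) gives 15.8 ug/mL. Compound 2 therefore holds the higher of the two numbers, and the gap between them lies beyond the usual scatter of repeated measurements.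

The next compound to consider is compound 3 (`CN(C)CCCNc1nc2cc([N+](=O)[O-])ccc2nc1NCc1ccc(Cl)c(C(F)(F)F)c1`). It carries 4-chloro-3-(trifluoromethyl)phenyl in place of the 4-methylphenyl of compound 2, on a saturated chain carbon bound to a nitrogen on an aromatic ring: 4-chloro-3-(trifluoromethyl)phenyl in place of 4-methylphenyl on a saturated chain carbon bound to a nitrogen on an aromatic ring.

Among the compounds with values here, no measured pair shows this change on its own, so any forecast is tentative. The closest guide is compound 1, which also carries a trifluoromethyl group and gives 6.99 ug/mL. On that slim evidence, a modest move toward stronger inhibition in this assay is expected, close to the edge of the scatter: a 2.1-fold lower number from compound 2 to compound 3 (0.32 log units; beyond the scatter). For compound 3 the estimated value is 7.5 ug/mL, with an expected range from 3 ug/mL to 18 ug/mL.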

Compound 3, half-maximal inhibitory concentration: 3.26 ug/mL
Estimate against measurement, compound 3: 2.3-fold (0.36 log units) above; measured number inside the range.
By their numbers in this assay, from the lowest: compound 3; then compound 1; then compound 2.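

In this assay, replacing the 4-methylphenyl with 4-chloro-3-(trifluoromethyl)phenyl gives a 4.8-fold lower number from compound 2 to compound 3 (0.69 log units; beyond the scatter), a step beyond the scatter. Within the data shown here, this is the first comparison in which only one place differs, and it shows that the number responds to the group held on this saturated chain carbon bound to a nitrogen on an aromatic ring. The change keeps a six-membered aromatic ring of carbon only, with no hydrogen-bond donors or acceptors and no net charge in either group, but nothing measured here bears on why the number falls.

Chlorine and trifluoromethyl arrive together in this step, so the compounds shown cannot assign the drop to either one, and a phenyl ring carrying only chlorine or only trifluoromethyl would be needed to separate them. Going by these compounds, it also remains open whether the trend would hold for a different kind of substituent on this ring, such as an amine or a carboxylic acid, since a single step gives a direction for one change and no general rule for this position.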